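This account rests on a few compounds, and the source may have more. Where it says the series, first, only, none or still open, it means among the compounds named here.

Compound 1 `O=C(Nc1cccc(-n2cc(-c3ccncc3)c(-c3cc(O)cc(Cl)c3)n2)c1)Nc1ccc(Cl)c(C(F)(F)F)c1` is tested in a functional assay on OVCAR-3 cells (Homo sapiens) for inhibition, read by sulforhodamine B assay, with a stated time of 48 h (on this read-out lower numbers stand for stronger inhibition and higher numbers for weaker inhibition), where compound 1 gives 2340 nM. Going by the values given here, of the two compounds measured so far, compound 1 has the highest number; its only neighbour is compound 2 `O=C(Nc1cccc(-n2cc(-c3ccncc3)c(-c3cc(O)cc(Cl)c3)n2)c1)Nc1ccc(Cl)c(Cl)c1`, which in this assay gives 1960 nM, and the step of a 1.2-fold lower number from compound 1 to compound 2 (0.08 log units; within the scatter) lies within the scatter of repeated measurements, so the two compounds cannot be told apart on this read-out. Compound 3 `COc1cc(Cl)cc(-c2nn(-c3cccc(NC(=O)Nc4ccc(Cl)c(C(F)(F)F)c4)c3)cc2-c2ccncc2)c1` has not yet been measured. It differs from compound 1 by methyl in place of hydrogen on an oxygen on an aromatic ring, so that the hydroxy becomes a methoxy and the 3-chloro-5-hydroxyphenyl group becomes 3-chloro-5-methoxyphenyl. Among the compounds with values here, the one measured step, from compound 1 to compound 2, concerns a chloro in place of trifluoromethyl and says nothing about a methyl placed on an oxygen on an aromatic ring. Within the data shown here, with no step that bears on this change, the expectation rests on the value of compound 1 alone. For compound 3 the estimated step of a 1.0-fold lower number from compound 1 to compound 3 (0.01 log units; within the scatter) is therefore taken to be none beyond the scatter, with a wide range. Compound 3 is accordingly expected to give 2300 nM in this assay, between 700 nM and 7500 nM.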

Compound 3, half-maximal inhibitory concentration: 450 nM
Compound 3: the middle estimate sits 5.1-fold (0.71 log units) above what was measured; measured number below the stated range.
By their numbers in this assay, from the lowest: compound 3; then compounds 2 and 1 (each within the scatter of the next).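

In this assay, going by these compounds alone, turning the hydroxy of the 3-chloro-5-hydroxyphenyl group into a methoxy gives a 5.2-fold lower number from compound 1 to compound 3 (0.72 log units; beyond the scatter), whereas the only earlier step, chloro in place of trifluoromethyl, gave a 1.2-fold lower number from compound 1 to compound 2 (0.08 log units; within the scatter). This is therefore the first change among these compounds to move the number beyond the scatter, and it shows that a hydrogen on this oxygen is not required for inhibition on this read-out, since replacing it with methyl gives stronger inhibition. No measurement on these compounds accounts for the gain, so it remains an observation about this single change.

In the compounds shown, this oxygen carries only hydrogen or methyl, so it remains open whether the gain is specific to methoxy or would extend to a longer chain such as ethoxy, and how an amine in place of the oxygen would compare. Going by these compounds, it also remains open whether the same step would hold on the core of compound 2, which carries chloro in place of trifluoromethyl, as the step has been read only from compound 1.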